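Coumarin series: isobutoxy in place of ethoxy

The source may report more compounds than this note shows. Statements on the series, on what has been measured and on what is new or still open speak of the compounds shown alone.

Three compounds have numbers in a functional assay on KB cells (Homo sapiens) for antiproliferative activity, read by sulforhodamine B assay, with a stated time of 72 h; a higher number here means a weaker inhibitor of growth, a lower number a stronger inhibitor of growth. Compound 1 `COC(=O)c1cccc(CSc2ccc3c(C)cc(=O)oc3c2)c1` gives 2060 nM in this assay. For compound 2 `CCc1oc2c(C)c(OCc3ccccc3)ccc2c(=O)c1Br` this assay reports only a limit, > 26700 nM. For compound 3 `CCOc1ccc2c(=O)cc(CC)oc2c1CBr` this assay likewise reports only a limit, > 32100 nM; so compound 3 stands at one of the two limits of the set, (the limit of > 32100 nM in this assay, at which 1 of the 3 values shown sits), beside the other, (the limit of > 26700 nM in this assay, at which 1 of the 3 values shown sits), while compound 1 alone has a measured number. Compound 4 `CCc1cc(=O)c2ccc(OCC(C)C)c(CBr)c2o1` differs from compound 3 by isopropyl in place of methyl on a saturated chain carbon bound to an oxygen on an aromatic ring. Going by the values given here, no single-change step between measured compounds exists, so no direction is set; the expectation is no step beyond the scatter, a step that the limit leaves unreadable from compound 3 to compound 4, leaving compound 4 near the limit. Compound 4 is expected at 35000 nM, between 9000 nM and 120000 nM.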

Compound 4, concentration for 50% growth inhibition: > 29400 nM
Compound 4 ended at the assay's limit; the forecaster's own chance of this, stated with the estimate: 70%; the middle value lies beyond the limit too.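

Going by these compounds alone, compound 3 and compound 4 both stand only as limits in this assay, so no step between them can be read. From the compounds shown here alone, how far ethoxy and isobutoxy differ in growth inhibition on the shared core stays open.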